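Fluorophenyl series: clearance notes ahead of compound 3

A few compounds are considered here, and "the series" means these few. Any claim that something is new, unique, unknown or untested is made for them only; others in the source may bear on it.

Measured so far in an ADME assay on microsomes from liver (Homo sapiens) for metabolic stability, tested at 2.5 uM; a lower number here means slower removal, a higher number faster removal of the compound:
- compound 1, `O=S(=O)(c1ccc(F)c(Cl)c1)c1cnc2c(F)cccc2c1-c1ccccc1F`: 1.39 mL/min
- compound 2, `O=S(=O)(c1ccc(F)c(Cl)c1)c1cnc2c(F)cccc2c1-c1ccc(F)cc1`: 0.19 mL/min

For the measured compounds named here, compound 2 stands lowest of the two numbers in this assay; its only neighbour is compound 1, and the step of a 7.3-fold lower number from compound 1 to compound 2 (0.86 log units; beyond the scatter) separates them, a move that lies beyond the scatter and rests on 4-fluorophenyl in place of 2-fluorophenyl on an aromatic carbon.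

Compound 3, `O=S(=O)(c1ccc(F)c(Cl)c1)c1cnc2c(F)cccc2c1-c1ccc(Cl)cc1`, is the next member and is still to be measured in this assay. Relative to compound 2 the change is chloro in place of fluoro on an aromatic carbon, placed on an aromatic carbon of a six-membered aromatic ring of carbon only, para to a large group.

Going by the values given here, no measured step exchanges chloro for fluoro; the only step known, a 7.3-fold lower number from compound 1 to compound 2 (0.86 log units; beyond the scatter), concerns where the fluoro sits on the ring, not which halogen is present, so it bears on compound 3 only indirectly. With nothing else to go on, the step of a 1.3-fold higher number from compound 2 to compound 3 (0.12 log units; within the scatter) is expected to stay within the scatter. Compound 3 is therefore estimated at 0.25 mL/min, with a range from 0.1 mL/min to 0.6 mL/min.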

Compound 3, intrinsic clearance in a liver preparation (reported as CLH), per the amount of preparation that the assay uses: 0.01 mL/min
Beside the measured number, compound 3's estimate is 25-fold (1.40 log units) above it, and the stated range ends above it.
By their numbers in this assay, from the lowest: compound 3; then compound 2; then compound 1.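

In this assay the aromatic carbon para to a large group responds strongly to which halogen it carries, and not only to where a fluoro sits on the ring: chloro in place of fluoro gives a 19-fold lower number from compound 2 to compound 3 (1.28 log units; beyond the scatter) even though one heavy atom is exchanged for another and the counts of rings, hydrogen-bond donors, hydrogen-bond acceptors and net charge stay the same. Read against the 2-fluorophenyl starting point, 4-chlorophenyl gives a 140-fold lower number from compound 1 to compound 3 (2.14 log units; beyond the scatter) and so shows that changes on this one ring, with the shared core held constant, can span a wide range of numbers in this assay within this small set. Nothing at hand accounts for the size of the fluoro to chloro step, and its origin stays unassigned.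

The compounds shown leave open whether the low number is particular to chloro or extends to other groups on the same carbon, such as bromo, methyl, methoxy or an amine. They also leave open how chloro would behave elsewhere on this ring, and whether the same exchange would give a step of similar size on another core.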